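This account rests on a few compounds, and the source may have more. Where it says the series, first, only, none or still open, it means among the compounds named here.

Series notes, sulfonate esters on a shared core. For the measured compounds named here, in an ADME assay on Vero cells (Chlorocebus sabaeus) for cytotoxicity, read by polymerase chain reaction, with a stated time of 18 h (on this read-out lower numbers stand for higher toxicity in this test and higher numbers for lower toxicity in this test), compound 1 `Cc1ccc(S(=O)(=O)Oc2ccc3c(CSc4nc5ccc(C)cc5c(=O)[nH]4)cc(=O)oc3c2)cc1` gives 114000 nM and compound 2 `Cc1ccc2nc(SCc3cc(=O)oc4cc(OS(=O)(=O)c5ccc(F)cc5)ccc34)[nH]c(=O)c2c1` gives 86400 nM; the step of a 1.3-fold lower number from compound 1 to compound 2 (0.12 log units; within the scatter) is the only measured comparison and lies within the scatter, so compound 2 has the lower of the two numbers without a real ordering between them. Compound 3 `Cc1ccc2nc(SCc3cc(=O)oc4cc(OS(=O)(=O)c5ccccc5[N+](=O)[O-])ccc34)[nH]c(=O)c2c1` differs from compound 2 by 2-nitrophenyl in place of 4-fluorophenyl on a sulfonyl sulfur. Going by the values given here, the one step at this position, from compound 1 to compound 2, was small, so no step beyond the scatter is expected in this assay. Compound 3 is estimated at 90000 nM (range 40000 nM to 200000 nM), a step of a 1.0-fold higher number from compound 2 to compound 3 (0.02 log units; within the scatter) expected from compound 2.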

Compound 3, half-maximal cytotoxic concentration: 107000 nM
Compound 3: middle estimate off by 1.2-fold (0.08 log units), on the low side; the measured number falls inside the stated range.
By their numbers in this assay, from the lowest: compounds 2, 3 and 1 (each within the scatter of the next).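

With 2-nitrophenyl on the sulfonyl sulfur in this assay the new steps read a 1.2-fold higher number from compound 2 to compound 3 (0.09 log units; within the scatter) and a 1.1-fold lower number from compound 1 to compound 3 (0.03 log units; within the scatter) and neither separates the compounds. This position therefore now holds three substituted phenyl groups with no resolved ordering, and the added hydrogen-bond acceptors of 2-nitrophenyl go with no step beyond the scatter. Nothing available explains this result. On these data alone, what stays open is whether an aminophenyl group, a phenyl ring bearing a carboxylic acid or a straight butyl chain on the sulfonyl sulfur would give a step beyond the scatter.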